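Second hydroxyphenyl swap: what compound 4 may give

This account rests on a few compounds, and the source may have more. Where it says the series, first, only, none or still open, it means among the compounds named here.

Compound 1, `COc1cc(/C=C/C(=O)C2=C(/C=C/c3ccc(O)c(OC)c3)NC(=O)NC2c2ccc(C)cc2)ccc1O`, gives 38.2% in a functional assay, with a stated time of 20 min, tested at 20 uM; on this read-out lower numbers stand for a weaker effect and higher numbers for a stronger effect at the one concentration tested. Compound 2, `COc1cc(/C=C/C(=O)C2=C(/C=C/c3ccc(O)c(OC)c3)NC(=O)NC2c2ccccc2O)ccc1O`, gives 81% in this assay. Compound 3, `COc1cc(/C=C/C(=O)C2=C(/C=C/c3ccc(O)c(OC)c3)NC(=S)NC2c2ccc(C)cc2)ccc1O`, gives 51% in this assay.

Among the compounds with values here, the one counted change among the measured compounds is 2-hydroxyphenyl in place of 4-methylphenyl on a saturated ring carbon, and it made the step of a number 42.8 percentage points higher from compound 1 to compound 2 (beyond the scatter). Compound 3 carries a different core from compound 1; the difference between the two cores is not broken down here. Its value in this assay stands between those of compound 1 and compound 2, beyond the scatter from each.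

Compound 4, `COc1cc(/C=C/C(=O)C2=C(/C=C/c3ccc(O)c(OC)c3)NC(=S)NC2c2ccccc2O)ccc1O`, is not yet measured. It differs from compound 3 by 2-hydroxyphenyl in place of 4-methylphenyl on a saturated ring carbon, the same change seen from compound 1 to compound 2. Resting on the step of a number 42.8 percentage points higher from compound 1 to compound 2 (beyond the scatter) seen in compound 2, a step of a number 35 percentage points higher from compound 3 to compound 4 (beyond the scatter) is expected for compound 4, somewhat smaller because compound 3 already gives 51% and the read-out cannot rise far above full activity. Compound 4 is therefore estimated at 86%, between 65% and 98%.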

Compound 4, a percentage reported as activity, at one concentration (the size of the read-out at that concentration, not a potency): 72.3%
Compound 4: the middle estimate sits 13.7 percentage points above what was measured; measured number inside the range.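

On the core of compound 3, 2-hydroxyphenyl in place of 4-methylphenyl again raised the read-out in this assay, giving a number 21.3 percentage points higher from compound 3 to compound 4 (beyond the scatter). The direction of the change carried over from one core to the other, but its size did not: the same change on two cores in this assay, a number 42.8 percentage points higher (beyond the scatter) from compound 1 to compound 2 and a number 21.3 percentage points higher (beyond the scatter) from compound 3 to compound 4, 21.5 percentage points apart, beyond the scatter of two such steps. These two pairs show that the direction held on these two cores only; they do not show why the size differs or what the step would be on any further core.

The compounds shown leave open whether an aminophenyl or a carboxyphenyl group on the saturated ring carbon would give a similar rise on either core.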